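A few compounds are considered here, and "the series" means these few. Any claim that something is new, unique, unknown or untested is made for them only; others in the source may bear on it.

The measured compounds and their values in an ADME assay on L02 cells (Homo sapiens) for inhibition, read by CCK-8 assay, with a stated time of 48 h; a lower number here means a stronger inhibitor of growth, a higher number a weaker inhibitor of growth:

Compound 1, `Cc1ccccc1Nc1nc(Nc2ccc(N3CCCCC3)cn2)ncc1Cl`, gives 42400 nM.
Compound 2, `Cc1ccccc1Nc1nc(Nc2ccc(N3CCN(C(=O)OC(C)(C)C)CC3)cc2)ncc1Cl`, gives 1750 nM.
Compound 3, `COc1cccc(CNc2nc(Nc3ccc(N4CCN(C)CC4)cn3)ncc2Cl)c1`, gives 16200 nM.

Among these three numbers compound 3 stands second highest. Its nearest neighbour is compound 1, whose number is higher by a margin beyond the scatter, and its furthest is compound 2, whose number is lower by a margin well beyond the scatter. For the measured compounds named here, no pair among the measured compounds differs in one place only, so the three values show where each compound sits and not what any single change does.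

Compound 4 is `Cc1cc(C)c(Nc2nc(Nc3ccc(N4CCN(C)CC4)cn3)ncc2Cl)c(C)c1`. It differs from compound 3 in one place: 2,4,6-trimethylphenyl in place of 3-methoxybenzyl on a nitrogen on an aromatic ring. The leaving and entering groups carry the same count of heavy atoms and each holds one six-membered aromatic ring of carbon only; the leaving group brings one hydrogen-bond acceptor, the entering group none. Nothing measured here isolates such a change in this assay. Compound 3 is differed from at more than one place by compound 1, and the value of compound 1, 42400 nM, cannot be tied to the group on this nitrogen alone. On this footing a step within the scatter is expected, and the expected step is a 1.2-fold higher number from compound 3 to compound 4 (0.09 log units; within the scatter). Compound 4 is estimated at 20000 nM, with a range from 7000 nM to 60000 nM.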

Compound 4, concentration for 50% growth inhibition: 20500 nM
Beside the measured number, compound 4's estimate is 1.0-fold (0.01 log units) below it, within the range that was stated.
By their numbers in this assay, from the lowest: compound 2; then compounds 3 and 4 (each within the scatter of the next); then compound 1.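

In this assay, for the compounds shown here, 2,4,6-trimethylphenyl in place of 3-methoxybenzyl on a nitrogen on an aromatic ring gives a 1.3-fold higher number from compound 3 to compound 4 (0.10 log units; within the scatter), the first step in this set that can be read at a single place. The two groups carry the same count of heavy atoms and each holds one six-membered aromatic ring of carbon only, but they differ in the oxygen and the hydrogen-bond acceptor that only 3-methoxybenzyl brings, and in the arrangement of their carbons, and this whole exchange stays within the scatter in this assay. Nothing measured on these compounds bears on why the two numbers stand so close.

A single exchange leaves open whether other groups on this nitrogen, such as a plain phenyl, a dimethylaminoethyl chain or a benzoic acid, would move the number beyond the scatter. It also leaves open whether this exchange would read the same with other groups elsewhere on the shared core.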